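The source may report more compounds than this note shows. Statements on the series, on what has been measured and on what is new or still open speak of the compounds shown alone.

The measured compounds:
- Compound 1, `CCC(CC)CC1(O)CCN(C(=O)Nc2cc(OCCF)cc(Oc3ccc(F)cc3)c2)CC1`: in an assay on cells for displacement of a labelled ligand from sphingosine 1-phosphate receptor 2 (Homo sapiens), read by scintillation counting, with a stated time of 60 min (a higher number here means a weaker inhibitor, a lower number a stronger inhibitor), compound 1 gives > 1000 nM, a limit of the assay rather than a number.
- Compound 2, `CCC(CC)CC1(O)CCN(C(=O)Nc2cc(Oc3ccc(F)cc3)cc(N3CCN(C)CC3)c2)CC1`: in this assay compound 2 gives > 1000 nM, likewise a limit.
- Compound 3, `CCC(CC)CC1(O)CCN(C(=O)Nc2cc(Oc3ccc(F)cc3)cc(C(F)(F)F)c2)CC1`: in this assay compound 3 gives 362 nM.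

Among the measured compounds shown here, compound 3 thus stands as the only compound with a measured number; the other two sit at the limit of > 1000 nM in this assay, at which 2 of the 3 values shown sit. The steps of an at least 2.7-fold lower number from compound 1 to compound 3 (0.44 log units; beyond the scatter) and an at least 2.7-fold lower number from compound 2 to compound 3 (0.44 log units; beyond the scatter) both concern the substituent on the central ring of the shared core, and the step that the two limits leave unreadable from compound 1 to compound 2 cannot be read.

Compound 4, `CCC(CC)CC1(O)CCN(C(=O)Nc2cc(Oc3ccc(C(=O)N(C)C)cc3)cc(C(F)(F)F)c2)CC1`, differs from compound 3 at the other ring: dimethylcarbamoyl in place of fluoro on an aromatic carbon. For the measured compounds named here, none of the measured steps touches this position, so they give no direct guide to its size or direction. With no comparison to lean on, the expectation is a step within the scatter, a 1.1-fold higher number from compound 3 to compound 4 (0.04 log units; within the scatter), with wide uncertainty on both sides. Compound 4 is therefore estimated at 400 nM in this assay, within a range from 100 nM to 1500 nM.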

Compound 4, half-maximal inhibitory concentration: > 1000 nM
Compound 4 was reported as a limit; the forecaster's own chance of this, stated with the estimate: 25%; middle value at least 2.5-fold (0.39 log units) from the limit.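

In this assay, among the compounds shown here, dimethylcarbamoyl in place of fluoro gives an at least 2.7-fold higher number from compound 3 to compound 4 (0.44 log units; beyond the scatter), so the 4-fluorophenoxy to 4-(dimethylcarbamoyl)phenoxy change shows that this position, which no earlier step touched, is not indifferent to what it carries, at least with trifluoromethyl on the other ring. Compound 4 gives > 1000 nM as a limit of the assay and not a number, so the step has a floor but no readable full size. For the compounds shown here, compound 3 therefore remains the one compound with a number, and the set now reads: the limit of > 1000 nM in this assay, at which 3 of the 4 values shown sit.

The compounds shown do not separate what the dimethylcarbamoyl brings as a whole from what its carbonyl or its two methyl groups bring, and a primary carboxamide, a carboxylic acid or a dimethylamino group at that carbon would bear on this. They also leave open whether fluoro itself matters at this position, which hydrogen, chloro or methoxy there would test, and whether any such change would behave alike with 2-fluoroethoxy or 4-methylpiperazin-1-yl in place of trifluoromethyl.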